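The source may report more compounds than this note shows. Statements on the series, on what has been measured and on what is new or still open speak of the compounds shown alone.

Compound 1 `O=C(O)CCNC(=O)c1ccc(CN(c2ccc3c(c2)CCC3)c2nc(-c3ccc(C(F)(F)F)cc3)cs2)cc1`: 5400 nM
Compound 2 `O=C(O)CCNC(=O)c1ccc(CN(c2ccc3c(c2)CCCC3)c2nc(-c3ccc(Cl)c(Cl)c3)cs2)cc1`: 1600 nM

In an assay on membranes from liver for binding affinity to Glucagon receptor (Rattus norvegicus) (a higher number here means a weaker inhibitor, a lower number a stronger inhibitor), compound 1 gives 5400 nM, the higher of the two numbers. Compound 2 gives 1600 nM, and the gap between the two lies beyond the usual scatter; the two compounds differ in more than one place, so no single change can be read from this gap. Compound 3 `O=C(O)CCNC(=O)c1ccc(CN(c2ccc(OC(F)(F)F)cc2)c2nc(-c3ccc(C(F)(F)F)cc3)cs2)cc1` is not yet measured. It differs from compound 1 in one place: 4-(trifluoromethoxy)phenyl in place of 2,3-dihydro-1H-inden-5-yl on a nitrogen on an aromatic ring. Within the data shown here, no measured pair shows this change alone, so its effect is unknown here. A small step, expected to stay within the scatter, is taken as a 1.4-fold lower number from compound 1 to compound 3 (0.13 log units; within the scatter). For compound 3 the estimate in this assay is 4000 nM, with a range from 900 nM to 15000 nM.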

Compound 3, half-maximal inhibitory concentration: 2000 nM
Compound 3: middle estimate off by 2.0-fold (0.30 log units), on the high side; the range from low to high includes it.
By their numbers in this assay, from the lowest: compounds 2 and 3 (each within the scatter of the next); then compound 1.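

On the nitrogen on an aromatic ring, 4-(trifluoromethoxy)phenyl in place of 2,3-dihydro-1H-inden-5-yl gives a 2.7-fold lower number from compound 1 to compound 3 (0.43 log units; beyond the scatter) in this assay. This modest step shows that this position alone can shift the number, something the earlier pair, differing in more than one place, could not show. No measurement shown here explains the shift.

Still open, from the compounds shown here alone, is which part of the new group matters: a plain phenyl or a 4-methoxyphenyl at this place would help to tell. Going by these compounds, whether the step would repeat with the 3,4-dichlorophenyl of compound 2 also remains open.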